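Adding a methyl to the side chain of compound 2

The compounds below may be only part of what the source reports. "The series", "measured", "known", "first", "only" and "open" are said of these compounds alone.

Going by the values given here, in a functional assay on HT-29 cells (Homo sapiens) for inhibition, read by sulforhodamine B assay, with a stated time of 96 h (a higher number here means a weaker inhibitor of growth, a lower number a stronger inhibitor of growth), compound 2 `CC[C@H](Nc1nc(NCc2ccccn2)c2ncn(C(C)C)c2n1)C(C)O` gives 20000 nM, the only actual number so far. Compound 1 `CC[C@@H](Nc1nc(NCc2ccccn2)c2ncn(C(C)C)c2n1)C(C)(C)O` reads > 50000 nM, which is a limit of the assay and not a number. Among the compounds with values here, the one measured step, an at least 2.5-fold lower number from compound 1 to compound 2 (0.39 log units; beyond the scatter), starts from the limit of > 50000 nM in this assay, at which 1 of the 2 values shown sits. Compound 3 `CCC(O)[C@H](CC)Nc1nc(NCc2ccccn2)c2ncn(C(C)C)c2n1` has yet to be measured. It differs from compound 2 by methyl in place of hydrogen on a saturated chain carbon, two bonds along the chain from an oxygen on a saturated carbon, which turns 1-(1-hydroxyethyl)propyl into 1-ethyl-2-hydroxybutyl. The measured step bears on this only loosely: it changed the same side chain in another way, and the 1-(1-hydroxy-1-methylethyl)propyl group of compound 1 carried the higher number. A small move towards a higher number is therefore expected, perhaps none beyond the scatter. The expected change is a 1.3-fold higher number from compound 2 to compound 3 (0.10 log units; within the scatter). For compound 3 the estimated value is 25000 nM, within an expected range of 10000 nM to 50000 nM.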

Compound 3, concentration for 50% growth inhibition: > 50000 nM
Compound 3 was reported as a limit (the forecaster's own chance of this, stated with the estimate: 25%); middle value at least 2.0-fold (0.30 log units) away from the limit.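

Methyl in place of hydrogen on a saturated chain carbon, two bonds along the chain from an oxygen on a saturated carbon, is a small change, yet it gives an at least 2.5-fold higher number from compound 2 to compound 3 (0.39 log units; beyond the scatter). In this assay compound 3 gives > 50000 nM, which is a limit of the assay and not a number. The 1-(1-hydroxyethyl)propyl group of compound 2 is now the only one of the three side chains to give a number, and the step between the other two compounds cannot be read: the limit of > 50000 nM in this assay, at which 2 of the 3 values shown sit.

From the compounds shown here alone, how far compound 3 lies beyond that limit stays open. Also open, going by these compounds, is whether a shorter hydroxymethyl side chain, or an amine in place of the hydroxyl, would give a lower number than compound 2 does.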